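The source may hold more compounds than are shown below. What is called first, only, known or untested is meant among the compounds shown, and "the series" means these compounds.

Of the compounds shown here, three have so far been measured in an assay on isolated protein for inhibition of acid ceramidase (Homo sapiens), read by LC-MS, with a stated time of 1 h; on this read-out higher numbers stand for weaker inhibition and lower numbers for stronger inhibition. Compound 1 `Cc1oc(=O)n(C(=O)NCCCCc2ccccc2)c1-c1ccccc1` gives 42 nM in this assay. Compound 2 `CCOCCNC(=O)n1cc(-c2ccccc2)oc1=O` gives 2040 nM in this assay. Compound 3 `COc1ccc(-c2cn(C(=O)NCCCCc3ccccc3)c(=O)o2)cc1` gives 400 nM in this assay, the second highest of the three numbers, standing closer to compound 2 than to compound 1, and beyond the scatter from both. Compound 4 `O=C(NCCCCc1ccccc1)n1cc(-c2cnccn2)oc1=O` has not yet been measured; it differs from compound 3 by pyrazin-2-yl in place of 4-methoxyphenyl on an aromatic carbon. Within the data shown here, no single-change step between measured compounds exists to guide the expectation, so the change is expected to shift the number in this assay only modestly, if at all, toward weaker inhibition. Compound 4 is therefore estimated at 600 nM, within a range of 150 nM to 2500 nM. The expected step of a 1.5-fold higher number from compound 3 to compound 4 (0.18 log units; within the scatter) would lie near the edge of the usual scatter.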

Compound 4, half-maximal inhibitory concentration: 32 nM
Compound 4: middle estimate off by 19-fold (1.27 log units), on the high side, and the stated range ends above it.
By their numbers in this assay, from the lowest: compounds 4 and 1 (each within the scatter of the next); then compound 3; then compound 2.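

Among these compounds, putting pyrazin-2-yl in place of 4-methoxyphenyl on the aromatic carbon next to the ring oxygen gives a 13-fold lower number from compound 3 to compound 4 (1.10 log units; beyond the scatter) in this assay, so inhibition at this position depends strongly on the ring it carries, something no earlier pair could show. A six-membered aromatic ring with 2 hetero atoms is thus accepted here, and with stronger inhibition than the carbon-only ring. Nothing available explains this gain. From the compounds shown here alone, whether it follows from the ring nitrogens or from losing the methoxy group stays open, as does the outcome with pyridin-2-yl or pyrimidin-2-yl at this position.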